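The source may hold more compounds than are shown below. What is called first, only, known or untested is meant among the compounds shown, and "the series" means these compounds.

Three compounds of the shared core carry a number or a limit in a functional assay on HeLa cells (Homo sapiens) for cytotoxicity, read by MTT assay, with a stated time of 7 h; a higher number here means a weaker inhibitor, a lower number a stronger inhibitor. Compound 1 `OCCNC(=S)Nc1ccnc2cc(Cl)ccc12` reaches only the limit of the assay, > 50000 nM, a limit and not a number. Compound 3 `CCN(CC)CCCNC(=S)Nc1ccnc2cc(Cl)ccc12` gives 49200 nM in this assay, and compound 2 `CCOC(=O)N1CCN(C(=S)Nc2ccnc3cc(Cl)ccc23)CC1` gives 40100 nM. Within the data shown here, the single step between compounds that differ in one place, an at least 1.0-fold lower number from compound 1 to compound 3 (0.00 log units; that floor lies within the scatter), has no measurable size because compound 1 sits at the limit of > 50000 nM in this assay, at which 1 of the 3 values shown sits. Compound 2 holds the lowest of the two numbers shown; its nearest neighbour is compound 3, at a gap within the scatter, so no order between them is read.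

Compound 4 `S=C(Nc1ccnc2cc(Cl)ccc12)N1CCN(c2ccccc2)CC1` is not yet measured. It differs from compound 2 by phenyl in place of ethoxycarbonyl on an amine nitrogen in a ring. No measured step touches the amine nitrogen in the ring; the one step shown, an at least 1.0-fold lower number from compound 1 to compound 3 (0.00 log units; that floor lies within the scatter), concerns a saturated chain carbon and lies within the scatter. Nothing in the series therefore supports a step beyond the scatter in either direction for this assay. Compound 4 is expected near 40000 nM, with a range from 18000 nM to 80000 nM. The step this estimate means, a 1.0-fold lower number from compound 2 to compound 4 (0.00 log units; within the scatter), is expected to stay inside the scatter.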

Compound 4, half-maximal inhibitory concentration: 43600 nM
The estimate for compound 4 lay 1.1-fold (0.04 log units) below the measured number; low and high end bracket the measured number.
By their numbers in this assay, from the lowest: compounds 2, 4 and 3 (each within the scatter of the next). At a limit, above all of these: compound 1.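

In this assay, among these compounds, the change on the amine nitrogen in the ring gives a 1.1-fold higher number from compound 2 to compound 4 (0.04 log units; within the scatter) and is the first step measured at this place. Ethoxycarbonyl, with no ring and 2 hydrogen-bond acceptors, gives way here to phenyl, with one six-membered aromatic ring of carbon only and 0 hydrogen-bond acceptors, and the step still stays within the scatter. The earlier compounds shown here held no step at this position; the pair now shows that these two groups cannot be told apart on it, and neither is ranked over the other.

From the compounds shown here alone, whether an amine, a carboxylic acid or a longer chain on this ring nitrogen would give a step beyond the scatter stays open. Compound 1 remains a limit and not a number: the limit of > 50000 nM in this assay, at which 1 of the 4 values shown sits.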